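Swapping chloro for amino on a long-chain compound

The source may report more compounds than this note shows. Statements on the series, on what has been measured and on what is new or still open speak of the compounds shown alone.

Measured so far in a functional assay on HCT-116 cells (Homo sapiens) for antiproliferative activity, read by MTT assay, with a stated time of 48 h; a higher number here means a weaker inhibitor, a lower number a stronger inhibitor:
- compound 1 `CCCCC(CCO)n1cnc2c(N)ncnc21` gives > 50000 nM as a limit
- compound 2 `CCCCCCCCCCC(CCO)n1cnc2c(Cl)ncnc21` gives 4930 nM as a number

Among the measured compounds shown here, compound 2 at 4930 nM holds the only exact number so far. Compound 3 `CCCCCCCCCCC(CCO)n1cnc2c(N)ncnc21` puts amino in place of chloro on an aromatic carbon and keeps the rest of compound 2 unchanged. Compound 1 also carries amino and shows > 50000 nM as a limit of the assay, though its side chain differs. A moderate step towards weaker inhibition, beyond the scatter, is therefore expected. The estimated move in this assay is a 2.4-fold higher number from compound 2 to compound 3 (0.39 log units; beyond the scatter) on this reasoning. Compound 3 is expected at 12000 nM within a range of 4000 nM to 40000 nM once measured.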

Compound 3, half-maximal inhibitory concentration: 2590 nM
For compound 3 the middle estimate is 4.6-fold (0.67 log units) above the measured one; measured number outside the range, below it.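

In this assay, amino in place of chloro on an aromatic carbon gives a 1.9-fold lower number from compound 2 to compound 3 (0.28 log units; within the scatter), so on the long chain the two groups cannot be told apart at this position. Between the two amino compounds, hexyl in place of hydrogen on a saturated chain carbon gives an at least 19-fold lower number from compound 1 to compound 3 (1.28 log units; beyond the scatter). Compound 1 gives > 50000 nM, which is a limit, so this step has no exact size: the limit of > 50000 nM in this assay, at which 1 of the 3 values shown sits.

On these data alone, whether a methoxy or dimethylamino group at this position would give a similar number remains open. So does the effect of a longer chain.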